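From Compound 2 to Compound 4: a Ring Swap

The source may hold more compounds than are shown below. What is called first, only, known or untested is meant among the compounds shown, and "the series" means these compounds.

Three compounds have so far been run in a functional assay on LM7 cells (Homo sapiens) for cytotoxicity, read by MTT assay, with a stated time of 72 h; a lower number here means a stronger inhibitor, a higher number a weaker inhibitor. Compound 1 `Cc1cc(C)nc(SCc2cc(=O)c3cc(Cl)ccc3o2)n1` reaches only a limit of the assay, > 25000 nM. Compound 2 `Cc1nnc(SCc2cc(=O)c3ccccc3o2)s1` likewise gives only a limit, > 25000 nM. Compound 3 `Cc1cc(O)cc2oc(=O)cc(CSc3nc4ccccc4[nH]3)c12` also stops at a limit, > 25000 nM. Among the measured compounds shown here, compound 2 therefore stands together with the other two at the limit of > 25000 nM in this assay, at which 3 of the 3 values shown sit, and no step between measured compounds can be drawn. Compound 4 `Cc1nnc(SCc2cc(=O)c3ccccc3o2)o1` has not yet been measured; it differs from compound 2 by 5-methyl-1,3,4-oxadiazol-2-yl in place of 5-methyl-1,3,4-thiadiazol-2-yl on a sulfur. Given (the limit of > 25000 nM in this assay, at which 3 of the 3 values shown sit), the step expected in this assay from compound 2 to compound 4 is none beyond the scatter, a step that the limit leaves unreadable from compound 2 to compound 4. Compound 4 is thus expected to give about 30000 nM, in a range from 15000 nM to 100000 nM, most likely again reported only as a limit.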

Compound 4, half-maximal inhibitory concentration: > 25000 nM
Compound 4: a limit, no number; the forecaster's own chance of this, stated with the estimate: 85%; the middle value lies beyond the limit too.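

Among the compounds shown here, compound 4 also stops at a limit, > 25000 nM, so no step from compound 2 to it can be read. The compounds shown leave open how 5-methyl-1,3,4-oxadiazol-2-yl and 5-methyl-1,3,4-thiadiazol-2-yl actually compare in cytotoxicity.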